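Exchanging the whole side group at one ring carbon

This account rests on a few compounds, and the source may have more. Where it says the series, first, only, none or still open, it means among the compounds named here.

Compound 3 `COc1ccc(-c2nnc(SCCCN3CCN(c4nc5ccccc5s4)CC3)o2)cc1` gives 134000 nM in a functional assay on HepG2 cells (Homo sapiens) for inhibition, read by MTT assay, with a stated time of 72 h (a higher number here means a weaker inhibitor, a lower number a stronger inhibitor), the highest of the three numbers measured, although its gaps to compound 2 `c1ccc(-c2nnc(SCCCN3CCN(c4nc5ccccc5o4)CC3)o2)cc1` at 102000 nM and to compound 1 `Fc1ccc(-c2nnc(SCCCN3CCN(c4nc5ccccc5o4)CC3)o2)cc1` at 83800 nM both lie within the scatter. Compound 4 `O=C(NCc1nnc(SCCCN2CCN(c3nc4ccccc4s3)CC2)o1)c1ccccc1` differs from compound 3 by benzamidomethyl in place of 4-methoxyphenyl on an aromatic carbon. For the measured compounds named here, the only measured step, a 1.2-fold higher number from compound 1 to compound 2 (0.09 log units; within the scatter), alters a single substituent on the very group that now leaves entirely, so it bears on this change only loosely, and it showed nothing beyond the scatter. Going by the values given here, no measured step covers the exchange of the whole group at that ring carbon. The expected step is therefore a 1.0-fold lower number from compound 3 to compound 4 (0.01 log units; within the scatter), not beyond the scatter. Compound 4 is thus estimated at 130000 nM, in a range from 50000 nM to 350000 nM.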

Compound 4, half-maximal inhibitory concentration: 325000 nM
For compound 4 the middle estimate is 2.5-fold (0.40 log units) below the measured one; the measured number falls inside the stated range.
By their numbers in this assay, from the lowest: compounds 1, 2 and 3 (each within the scatter of the next); then compound 4.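

In this assay benzamidomethyl in place of 4-methoxyphenyl gives a 2.4-fold higher number from compound 3 to compound 4 (0.38 log units; beyond the scatter) and so a weaker inhibitor. For the compounds shown here, this is the first step here to pass beyond the scatter, so this ring carbon can register an exchange of its whole side group, which the small hydrogen-for-fluoro step on the phenyl ring did not show. Nothing measured here says why the number rises.

The compounds shown leave open whether the amide hydrogen or the carbonyl of benzamidomethyl matters for this step. They also leave open how a plain amine or a carboxylic acid on this ring carbon would read.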